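Amino to Methoxy on an Aromatic Carbon: Expecting Compound 3

The source may report more compounds than this note shows. Statements on the series, on what has been measured and on what is new or still open speak of the compounds shown alone.

Compound 1 `COc1ccc(-c2cc(/C=C/C(=O)c3ccc(N)cc3)[nH]n2)cc1`: in a functional assay on SF-539 cells (Homo sapiens) for cytotoxicity, read by sulforhodamine B assay, with a stated time of 48 h, tested at 0.01 uM (on this read-out lower numbers stand for a stronger effect and higher numbers for a weaker effect at the one concentration tested), compound 1 gives 98%.
Compound 2 `COc1cc(-c2cc(/C=C/C(=O)c3ccc(N)cc3)[nH]n2)cc(OC)c1OC`: in this assay compound 2 gives 92%.

Of the two numbers, compound 2 has the lower one, but its nearest neighbour, compound 1, stands only a little higher, and that gap lies within the scatter of repeated measurements, so the two cannot be told apart. Both read-outs sit near the top of the scale, which means little effect at the single concentration tested.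

Compound 3 `COc1ccc(C(=O)/C=C/c2cc(-c3cc(OC)c(OC)c(OC)c3)n[nH]2)cc1` has not been measured. It differs from compound 2 in one place: methoxy in place of amino on an aromatic carbon. Among the measured compounds shown here, no pair of measured compounds shows what this exchange does, so the numbers give no ground for a shift in either direction. The step is expected to be no larger than the scatter, a number 2 percentage points higher from compound 2 to compound 3 (within the scatter). Compound 3 is therefore estimated at 94%, with a range from 80% to 105%.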

Compound 3, a percentage reported as activity, at one concentration (the size of the read-out at that concentration, not a potency): 97%
Estimate against measurement, compound 3: 3 percentage points below, within the range that was stated.
By their numbers in this assay, from the lowest: compounds 2, 3 and 1 (each within the scatter of the next).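

At this position, para to a large group on the six-membered aromatic ring of carbon only, methoxy in place of amino gives a number 5 percentage points higher from compound 2 to compound 3 (within the scatter). Among the compounds shown here, this is the first direct reading of the exchange, and it shows that amino is not needed to keep the read-out where it stands in this assay: neither compound can be told from the other, and the number stays near the top of the scale, at little effect. Nothing available explains this outcome or bears on it.

The compounds shown leave open whether another group at this position, such as a hydroxyl, a carboxylic acid or a dimethylamino group, would move the number beyond the scatter. With only one low concentration read, they also leave open whether amino and methoxy would differ at concentrations where the effect is stronger.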